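Aryl Substituent Changes and Cytotoxicity in Three Analogues

The source may hold more compounds than are shown below. What is called first, only, known or untested is meant among the compounds shown, and "the series" means these compounds.

Of the compounds shown here, three have so far been measured in an ADME assay on HepG2 cells (Homo sapiens) for cytotoxicity, read by MTT assay, with a stated time of 48 h, tested at 10 uM; a higher number here means a stronger effect of the compound at the concentration tested, a lower number a weaker effect.

Compound 1, `O=c1cc(-c2cccc(O)c2)oc2cc(OCCCCCCCCN3CCCC3)ccc12`, gives 43.9%.
Compound 2, `O=c1cc(-c2ccc(Cl)cc2)oc2cc(OCCCCCCCCN3CCCC3)ccc12`, gives 25.7%.
Compound 3, `O=c1cc(-c2ccccc2O)oc2cc(OCCCCCCCCN3CCCC3)ccc12`, gives 60.6%.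

Compound 2 stands lowest of the three, separated from both others beyond the scatter: the step of a number 18.2 percentage points lower from compound 1 to compound 2 (beyond the scatter) and the step of a number 34.9 percentage points higher from compound 2 to compound 3 (beyond the scatter) bracket it. Compound 4, `COc1ccccc1-c1cc(=O)c2ccc(OCCCCCCCCN3CCCC3)cc2o1`, differs from compound 2 by 2-methoxyphenyl in place of 4-chlorophenyl on an aromatic carbon. The step of a number 34.9 percentage points higher from compound 2 to compound 3 (beyond the scatter) bears most closely on this change, since the entering group shares its substitution position with the 2-hydroxyphenyl of compound 3, and the step of a number 18.2 percentage points lower from compound 1 to compound 2 (beyond the scatter) shows that removing the 4-chlorophenyl has so far raised the number. An increase beyond the scatter is therefore expected, of size a number 19.3 percentage points higher from compound 2 to compound 4 (beyond the scatter), though smaller than that to compound 3, as the 2-methoxyphenyl is not the 2-hydroxyphenyl. Compound 4 is thus estimated at 45%, within 28% to 62%.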

Compound 4, a percentage reported as inhibition, at one concentration (the size of the read-out at that concentration, not a potency): 24.3%
For compound 4 the middle estimate is 20.7 percentage points above the measured one, outside the stated range (below it).
By their numbers in this assay, from the lowest: compounds 4 and 2 (each within the scatter of the next); then compound 1; then compound 3.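

In this assay, the step of a number 36.3 percentage points lower from compound 3 to compound 4 (beyond the scatter) shows that the number seen with the 2-hydroxyphenyl does not carry over once methyl replaces the hydrogen on that oxygen. The step of a number 1.4 percentage points lower from compound 2 to compound 4 (within the scatter) leaves 2-methoxyphenyl and 4-chlorophenyl unseparated at this position, and the step of a number 19.6 percentage points lower from compound 1 to compound 4 (beyond the scatter) places the 3-hydroxyphenyl of compound 1 clear of the 2-methoxyphenyl. Nothing available explains these differences. From the compounds shown here alone, it remains open whether a 2-aminophenyl or 2-ethoxyphenyl here would stand with compound 3 or with compound 4. Also open, going by these compounds, is whether methyl on the oxygen of the 3-hydroxyphenyl would have a comparable effect.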